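A Flat Series Meets (Trifluoromethyl)sulfanyl in Place of Ethoxy

The source may hold more compounds than are shown below. What is called first, only, known or untested is meant among the compounds shown, and "the series" means these compounds.

In a functional assay on HeLa cells (Homo sapiens) for inhibition, read by MTT assay, with a stated time of 72 h (a lower number here means a stronger inhibitor, a higher number a weaker inhibitor), compound 1 (`C=C(Br)C(=O)Nc1cccc(/C=C/C(=O)Nc2ccc(Cl)cc2)c1`) gives 2800 nM, compound 2 (`C=C(Br)C(=O)Nc1cccc(/C=C/C(=O)Nc2ccc(C)cc2)c1`) gives 1500 nM and compound 3 (`C=C(Br)C(=O)Nc1cccc(/C=C/C(=O)Nc2ccc(OCC)cc2)c1`) gives 2000 nM. Compound 3 therefore cannot be told apart from either of the other two on these numbers. Compound 4 (`C=C(Br)C(=O)Nc1cccc(/C=C/C(=O)Nc2ccc(SC(F)(F)F)cc2)c1`) keeps the shared core and carries (trifluoromethyl)sulfanyl in place of ethoxy on an aromatic carbon, para to a large group: (trifluoromethyl)sulfanyl in place of ethoxy on an aromatic carbon. Among the measured compounds shown here, no measured compound carries the entering group, so the evidence is indirect. The three measured exchanges at that place are a 1.9-fold lower number from compound 1 to compound 2 (0.27 log units; within the scatter), a 1.4-fold lower number from compound 1 to compound 3 (0.15 log units; within the scatter) and a 1.3-fold higher number from compound 2 to compound 3 (0.12 log units; within the scatter). Each stays within the scatter, so no step beyond the scatter is expected in this assay, and neither direction is favoured. The expected step is a 1.1-fold higher number from compound 3 to compound 4 (0.02 log units; within the scatter). For compound 4 the estimated value is 2100 nM, with an expected range from 900 nM to 4800 nM.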

Compound 4, half-maximal inhibitory concentration: 19000 nM
Beside the measured number, compound 4's estimate is 9.0-fold (0.96 log units) below it, and the stated range ends below it.
By their numbers in this assay, from the lowest: compounds 2, 3 and 1 (each within the scatter of the next); then compound 4.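

Against the earlier trio, (trifluoromethyl)sulfanyl shows that the place para to a large group does respond in this assay, with a 9.5-fold higher number from compound 3 to compound 4 (0.98 log units; beyond the scatter) against ethoxy and a 13-fold higher number from compound 2 to compound 4 (1.10 log units; beyond the scatter) against methyl and a 6.8-fold higher number from compound 1 to compound 4 (0.83 log units; beyond the scatter) against chloro. All three steps lie beyond the scatter and run the same way, so compound 4 is the weakest inhibitor of the four, while compound 1, compound 2 and compound 3 remain a single group. The tolerance seen among chloro, methyl and ethoxy therefore does not extend to every group at this place.

As far as these compounds go, whether the loss follows the sulfur, the trifluoromethyl end or their combination stays open, and trifluoromethoxy, trifluoromethyl or methylsulfanyl at the same place would separate these. Nothing shown gives a measured reason for this step.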